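The source may report more compounds than this note shows. Statements on the series, on what has been measured and on what is new or still open speak of the compounds shown alone.

Compound 1 `Cc1nccn1-c1cnc(NCc2c(F)ccc3c2CCO3)c2cn[nH]c(=O)c12` — 7000 nM
Compound 2 `O=C1c2ccccc2CN1c1cnc(NCc2c(F)ccc3c2CCO3)n2cnnc12` — 4000 nM

In a physicochemical assay for solubility, read by LC-MS, in phosphate buffer, with a stated time of 24 h, at pH 7.4 (a higher number here means a more soluble compound, a lower number a less soluble compound), compound 1 gives 7000 nM and compound 2 gives 4000 nM. Compound 2 has the lower of the two numbers, yet its gap to compound 1 falls within the scatter, so the two read as alike. Compound 3 `C[C@H]1CC(=O)N(c2cnc(NCc3c(F)ccc4c3CCO4)n3cnnc23)C1` differs from compound 2 in one place: a group of 7 heavy atoms (5 carbon, 1 nitrogen, 1 oxygen; one five-membered non-aromatic ring with 1 hetero atom) in place of a group of 10 heavy atoms (8 carbon, 1 nitrogen, 1 oxygen; one five-membered non-aromatic ring with 1 hetero atom, one six-membered aromatic ring of carbon only), on an aromatic carbon. Within the data shown here, no measured pair shows what this change does in this assay; an upward step, somewhat beyond the scatter, is expected. Compound 3 is therefore estimated at 15000 nM, within 5000 nM to 45000 nM, an expected step of a 3.8-fold higher number from compound 2 to compound 3 (0.57 log units; beyond the scatter).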

Compound 3, solubility: 200000 nM
The estimate for compound 3 lay 13-fold (1.12 log units) below the measured number; the whole stated range lies below it.
By their numbers in this assay, from the lowest: compounds 2 and 1 (each within the scatter of the next); then compound 3.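

In this assay, putting 4-methyl-2-oxopyrrolidin-1-yl on this aromatic carbon, in place of the group carrying a six-membered aromatic ring of carbon only, gives a 50-fold higher number from compound 2 to compound 3 (1.70 log units; beyond the scatter). What sits at this position can therefore move the number a long way, even though the counted hydrogen-bond donors and acceptors stay the same. No measurement here explains the size of this step.

The change removes the aromatic ring, shrinks the group and adds a methyl and a stereocentre all at once, so these remain unseparated. Unmethylated 2-oxopyrrolidin-1-yl or the opposite stereoisomer would help pull them apart.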